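The compounds below may be only part of what the source reports. "The series", "measured", "known", "first", "only" and "open" are said of these compounds alone.

In a toxicity assay on MT4 cells (Homo sapiens) for cytotoxicity, read by MTT assay (a lower number here means that less compound is tolerated, a higher number that more compound is tolerated), compound 1 (`Cc1cc(-c2ccccc2Cl)cc(C)c1Oc1cc(N)nc(Nc2ccc(C#N)cc2)n1`) gives 25100 nM and compound 2 (`Cc1cc(-c2ccc(C#N)c(F)c2)cc(C)c1Oc1cc(N)nc(Nc2ccc(C#N)cc2)n1`) gives 5000 nM as the lower of the two numbers. Compound 3 (`Cc1cc(-c2ccc(C#N)c(C#N)c2)cc(C)c1Oc1cc(N)nc(Nc2ccc(C#N)cc2)n1`) carries cyano in place of fluoro on an aromatic carbon, ortho to a cyano group (cyano in place of fluoro on an aromatic carbon). Among the compounds with values here, the only measured step is a 5.0-fold lower number from compound 1 to compound 2 (0.70 log units; beyond the scatter) and it exchanged a whole substituent, so it bears only loosely on this smaller swap. The expected move in this assay (a 1.2-fold higher number from compound 2 to compound 3 (0.08 log units; within the scatter)) stays within the scatter, with no firm direction. Compound 3 is estimated at 6000 nM (expected range 2000 nM to 18000 nM).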

Compound 3, half-maximal cytotoxic concentration: 17600 nM
The estimate for compound 3 lay 2.9-fold (0.47 log units) below the measured number, within the range that was stated.
By their numbers in this assay, from the lowest: compound 2; then compounds 3 and 1 (each within the scatter of the next).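

In this assay, even the small exchange of fluoro for cyano, ortho to a cyano group, is not neutral here: the step is a 3.5-fold higher number from compound 2 to compound 3 (0.55 log units; beyond the scatter), beyond the scatter. The 3,4-dicyanophenyl and 2-chlorophenyl groups are not told apart, with a 1.4-fold lower number from compound 1 to compound 3 (0.15 log units; within the scatter), which leaves compound 2 alone with the lowest number of the three. No supporting data explain this difference.

Open, on these data alone, is how an amine or a carboxylic acid at this position would read, and whether the cyano group it sits ortho to is needed for this step.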